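Ester change on a furanyl dihydropyrimidinone series

The source may hold more compounds than are shown below. What is called first, only, known or untested is meant among the compounds shown, and "the series" means these compounds.

Measured compounds:
compound 1 `CC1=C(C(=O)OC(C)(C)C)C(c2ccoc2)NC(=O)N1`, 11%
compound 2 `CC1=C(C(=O)OCc2ccccc2)C(c2ccoc2)NC(=O)N1`, 41%
compound 3 `CC1=C(C(=O)OC(C)(C)C)C(c2ccoc2)NC(=S)N1`, 18%

In an assay on membranes from CHO cells for displacement of a labelled ligand from adenosine receptor A1 (Homo sapiens), read by scintillation counting, with a stated time of 60 min, tested at 1 uM (a lower number here means less inhibition, a higher number more inhibition at the concentration tested (going by the name of the read-out)), compound 1 gives 11%. The change to compound 2, (benzyl in place of tert-butyl on an oxygen next to a carbonyl group), gave a number 30 percentage points higher from compound 1 to compound 2 (beyond the scatter). Compound 3 carries a different core; the difference between the core of compound 3 and that of compound 1 is not broken down here. In this assay compound 3 gives 18%, within the scatter of compound 1.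

Compound 4 `CC1=C(C(=O)OCc2ccccc2)C(c2ccoc2)NC(=S)N1` is not yet measured. It differs from compound 3 by benzyl in place of tert-butyl on an oxygen next to a carbonyl group, the same change seen from compound 1 to compound 2. Given that compound 3 and compound 1 sit within scatter of one another, a step of similar size is expected: a number 27 percentage points higher from compound 3 to compound 4 (beyond the scatter), resting on a number 30 percentage points higher from compound 1 to compound 2 (beyond the scatter). Compound 4 is estimated at 45%, with a range from 25% to 65%.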

Compound 4, a percentage reported as inhibition, at one concentration (the size of the read-out at that concentration, not a potency): 25%
Beside the measured number, compound 4's estimate is 20 percentage points above it, and the stated range covers the measured number.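

In this assay benzyl in place of tert-butyl on an oxygen next to a carbonyl group gave a number 7 percentage points higher from compound 3 to compound 4 (within the scatter) and so did not keep on the core of compound 3 the size it had on the core of compound 1. The two steps differ in size: the same change on two cores in this assay, a number 30 percentage points higher (beyond the scatter) from compound 1 to compound 2 and a number 7 percentage points higher (within the scatter) from compound 3 to compound 4, 23 percentage points apart, beyond the scatter of two such steps. This rests on one pair per core and does not show how the change would behave on any other core, nor what about the core difference goes with the gap.

Open, going by these compounds, is whether an ethyl group on that oxygen would follow either step. Also open, on these data alone, is whether a carboxylic acid or an amide in place of the ester would do so.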